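This account rests on a few compounds, and the source may have more. Where it says the series, first, only, none or still open, it means among the compounds named here.

Measured compounds:
Compound 1 `C#C[C@@]1(O)[C@H](O)[C@@H](CO)O[C@H]1n1ccc(N)nc1=O` in an ADME assay on MT4 cells (Homo sapiens) for cytotoxicity, read by MTT assay, with a stated time of 96 h (on this read-out higher numbers stand for lower toxicity in this test and lower numbers for higher toxicity in this test), gives >= 100000 nM, which is a limit of the assay.
Compound 2 `O=C(O)CCC(=O)Nc1ccc(-c2nc3cc(C(F)(F)F)ccc3[nH]2)cc1` in this assay gives > 100000 nM, also a limit of the assay.

Both values shown stand at the limits described by the limit of > 100000 nM in this assay, at which 1 of the 2 values shown sits, and (the limit of >= 100000 nM in this assay, at which 1 of the 2 values shown sits), so compound 2 sits at the upper edge of what this assay reports, and no numerical toxicity is known for it. Compound 3 `O=C(CN1CCCCC1)Nc1ccc(-c2nc3cc(C(F)(F)F)ccc3[nH]2)cc1` has not yet been measured. It differs from compound 2 by piperidin-1-yl in place of carboxymethyl on a saturated chain carbon bound to a carbonyl carbon. Within the data shown here, no measured step is available to calibrate this change. The account therefore expects that the step from compound 2 to compound 3 in this assay could move toward lower numbers, by an at least 2.0-fold lower number from compound 2 to compound 3 (0.30 log units; that floor lies within the scatter), though it may well remain within scatter at the limit. For compound 3 the estimate is 50000 nM, with a range from 10000 nM to 100000 nM.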

Compound 3, half-maximal cytotoxic concentration: 6000 nM
The estimate for compound 3 lay 8.3-fold (0.92 log units) above the measured number; the whole stated range lies above it.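

In this assay, piperidin-1-yl in place of carboxymethyl on a saturated chain carbon bound to a carbonyl carbon gives an at least 16-fold lower number from compound 2 to compound 3 (1.22 log units; beyond the scatter), so this place can shift the read-out clearly beyond the scatter, which the two earlier compounds could not show. Among these compounds, compound 3, at 6000 nM, is also the first compound here with a number rather than a limit. The size of the step is only a bound, and the true gap may be wider, as the value of compound 2 is a limit of the assay: the limit of > 100000 nM in this assay, at which 1 of the 3 values shown sits.

The compounds shown leave open whether the step follows the amine nitrogen or the six-membered ring, which a dimethylamino group or a cyclohexyl ring at the same place would help to separate. As far as these compounds go, it also remains open how a longer chain between the carbonyl and the amine would read.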